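Nitro to methoxy exchange in a small agonist series

A few compounds are considered here, and "the series" means these few. Any claim that something is new, unique, unknown or untested is made for them only; others in the source may bear on it.

compound 1 `Nc1scc(-c2cccc([N+](=O)[O-])c2)c1C(=O)c1ccccc1`: 47%
compound 2 `Nc1scc(-c2ccc([N+](=O)[O-])cc2)c1C(=O)c1ccccc1`: 50%
compound 3 `COc1cccc(-c2csc(N)c2C(=O)c2ccccc2)c1`: 41%

All three were run in a functional assay on CHO cells for agonist activity at adenosine receptor A1 (Homo sapiens), read by fluorescence and ERK phosphorylation, with stated times of 30 min and 1.5 h, tested at 3 uM; a lower number here means a weaker effect, a higher number a stronger effect of the compound at the concentration tested. Compound 1 gives 47%, compound 2 gives 50% and compound 3 gives 41%; the three numbers lie within the scatter of one another, so no order is read from them. Compound 1 and compound 2 are built from the same atoms joined differently; the difference between the two cores is not broken down here. From compound 1 to compound 3 the change is methoxy in place of nitro on an aromatic carbon, and in this assay it made a number 6 percentage points lower from compound 1 to compound 3 (within the scatter).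

Compound 4 `COc1ccc(-c2csc(N)c2C(=O)c2ccccc2)cc1` is not yet measured. From compound 2 it carries methoxy in place of nitro on an aromatic carbon, the same kind of change as before, now para to a large group where in compound 3 it sits meta to a large group. For compound 4 a step of about a number 6 percentage points lower from compound 2 to compound 4 (within the scatter) in this assay is expected, resting on a number 6 percentage points lower from compound 1 to compound 3 (within the scatter). Compound 4 is estimated at 44%, expected between 30% and 58%.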

Compound 4, a percentage reported as activity, at one concentration (the size of the read-out at that concentration, not a potency): 52%
The estimate for compound 4 lay 8 percentage points below the measured number; the range from low to high includes it.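

In this assay, methoxy in place of nitro on an aromatic carbon, here para to a large group, gave a number 2 percentage points higher from compound 2 to compound 4 (within the scatter). Set beside the earlier step, the exchange does not differ between the two cores: the same change on two cores in this assay, a number 6 percentage points lower (within the scatter) from compound 1 to compound 3 and a number 2 percentage points higher (within the scatter) from compound 2 to compound 4, 8 percentage points apart, within the scatter of two such steps. This shows that the change carried across these two pairs without a step beyond the scatter, but it rests on a read-out at one concentration, so it does not show that potency is unchanged or that the same would hold on other cores in the series.

The compounds shown leave open how an amine or a carboxylic acid would read in place of nitro or methoxy on this ring. On these data alone, a longer chain such as butoxy in the same place also remains open.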